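Carbamate dithiocarbamate triazoles: changing the benzyl substituent

The source may report more compounds than this note shows. Statements on the series, on what has been measured and on what is new or still open speak of the compounds shown alone.

For the measured compounds named here, compound 3 `Cc1ccc(Cn2cc(CSC(=S)N3CCN(C(=O)OCc4ccccc4)CC3)nn2)cc1` gives 37800 nM in a functional assay on MCF7 cells (Homo sapiens) for inhibition, read by MTT assay, with a stated time of 72 h (a lower number here means a stronger inhibitor, a higher number a weaker inhibitor), the highest of the three numbers measured so far. Compound 2 `Cc1ccc(Cn2cc(CSC(=S)N3CCN(C(=O)OC(C)(C)C)CC3)nn2)cc1` stands nearest with 19700 nM; the step of a 1.9-fold higher number from compound 2 to compound 3 (0.28 log units; within the scatter) lies within the scatter, so the two are not separable. Compound 1 `CC(C)(C)OC(=O)N1CCN(C(=S)SCc2cn(Cc3cc(=O)oc4cc(O)ccc34)nn2)CC1` gives 10400 nM, the furthest of the three and beyond the scatter from compound 3.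

Compound 4 `O=C(OCc1ccccc1)N1CCN(C(=S)SCc2cn(Cc3ccccc3F)nn2)CC1` has not been measured. It differs from compound 3 by 2-fluorophenyl in place of 4-methylphenyl on a saturated chain carbon bound to an aromatic nitrogen. Going by the values given here, no measured step touches this place. Among the compounds with values here, the only measured step, a 1.9-fold higher number from compound 2 to compound 3 (0.28 log units; within the scatter), concerns the ester group of the carbamate and is within the scatter, so it says nothing about the aromatic group on the chain carbon. Within the data shown here, compound 1 and compound 2 share the carbamate and differ in the group on that chain carbon, but no step is computed for that pair; what is known is that compound 1 gives 10400 nM while compound 2 gives 19700 nM, a gap beyond the scatter.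

With nothing bearing directly on the change, compound 4 is expected to stay near compound 3, and the estimated step of a 1.2-fold lower number from compound 3 to compound 4 (0.07 log units; within the scatter) is expected to fall within the scatter, in no settled direction. Compound 4 is therefore estimated at 32000 nM in this assay, with a range from 11000 nM to 95000 nM.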

Compound 4, half-maximal inhibitory concentration: 7950 nM
Compound 4: the middle estimate sits 4.0-fold (0.60 log units) above what was measured; the measured number lies below the stated range.
By their numbers in this assay, from the lowest: compounds 4, 1, 2 and 3 (each within the scatter of the next, the first and the last beyond it).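

In this assay, for the compounds shown here, the step of a 4.8-fold lower number from compound 3 to compound 4 (0.68 log units; beyond the scatter) is the first measured change at the group on a saturated chain carbon bound to an aromatic nitrogen, and it lies beyond the scatter, whereas the one earlier step, a 1.9-fold higher number from compound 2 to compound 3 (0.28 log units; within the scatter), at the carbamate ester group, does not. This place therefore responds to substitution in the benzyl carbamate series, even though 2-fluorophenyl and 4-methylphenyl have the same number of heavy atoms, the same aromatic ring and no hydrogen-bond donors or acceptors. Nothing at hand accounts for the size of this step, and the counted features of the two groups do not separate them beyond the element exchanged and its printed place.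

The exchange changes the substituent and its printed place together, so the step cannot be assigned to gaining 2-fluoro or losing 4-methyl; 4-fluorophenyl, 2-methylphenyl and unsubstituted phenyl on the same chain carbon would separate these. As far as these compounds go, whether 2-fluorophenyl gives a similar step in the tert-butyl carbamate series also remains open, as does the response to an amine or a carboxylic acid on this aromatic ring.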